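The source may hold more compounds than are shown below. What is called first, only, known or untested is meant among the compounds shown, and "the series" means these compounds.

Series notes. Among the compounds with values here, compound 1 `O=S(=O)(NCCNC(=S)Nc1ccc(Cl)cc1)c1ccc(-c2ccccc2OCc2ccccc2)s1` is the only member with a resolved number in a functional assay on HeLa cells (Homo sapiens) for inhibition, read by CCK-8 assay, with a stated time of 48 h; a higher number here means a weaker inhibitor, a lower number a stronger inhibitor: compound 1 gives 7000 nM. Compound 2 `COc1ccc(Oc2ccc([N+](=O)[O-])cc2-c2ccsc2S(=O)(=O)N2CCN(C(=S)Nc3ccc([N+](=O)[O-])cc3)CC2)cc1OC` returns only a limit in this assay, > 50000 nM. Compound 3 `CC(C)c1ccc(Oc2ccc(O)c(O)c2)c(-c2ccsc2S(=O)(=O)NCCNC(=O)Nc2cc(Cl)cc(Cl)c2)c1` likewise returns only a limit in this assay, > 50000 nM. Within the data shown here, compound 1 therefore stands alone as the one measurable point; the remainder of the series sits at the limit of > 50000 nM in this assay, at which 2 of the 3 values shown sit, and no step between two measured compounds is available to calibrate any change.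

Compound 4 `O=C(NCCNS(=O)(=O)c1ccc(-c2ccccc2OCc2ccccc2)s1)Nc1cccc([N+](=O)[O-])c1` is not yet measured. It differs from compound 1 by a group of 12 heavy atoms (7 carbon, 2 nitrogen, 3 oxygen; one six-membered aromatic ring of carbon only) in place of a group of 10 heavy atoms (7 carbon, 1 nitrogen, 1 sulfur, 1 chlorine; one six-membered aromatic ring of carbon only), on an amine nitrogen. The rest of the core of compound 1 is kept unchanged. Without a measured pair of this kind in the series, the size of the step in this assay can only be guessed: a modest loss is expected, of an order that a single repeat might not separate from the scatter, with a real chance that only a limit comes back. Compound 4 is accordingly expected to give 12000 nM in this assay, within 4000 nM to 40000 nM, meaning an estimated step of a 1.7-fold higher number from compound 1 to compound 4 (0.23 log units; within the scatter).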

Compound 4, half-maximal inhibitory concentration: > 20000 nM
Compound 4 was reported as a limit; the forecaster's own chance of this, stated with the estimate: 25%; at least 1.6-fold (0.22 log units) between middle value and limit.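

Compound 4 returns no resolved number in this assay, only a limit: the limit of > 20000 nM in this assay, at which 1 of the 4 values shown sits.

Within the data shown here, on the amine nitrogen of the core of compound 1, placing (3-nitrophenyl)carbamoyl in place of the original group gives the first readable step, an at least 2.8-fold higher number from compound 1 to compound 4 (0.45 log units; beyond the scatter). Among these compounds, because the value of compound 4 is a limit, this step gives only a minimum size, and compound 1 remains the only member with a resolved number.

The change replaces the sulfur and chlorine of the leaving group and brings in a nitro group in a single step, so the data do not show which part accounts for the loss. Going by these compounds, a (4-chlorophenyl)carbamoyl group or a (3-nitrophenyl)thiocarbamoyl group on the same amine nitrogen would separate these parts, and the full size of the step also remains open.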